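A few compounds are considered here, and "the series" means these few. Any claim that something is new, unique, unknown or untested is made for them only; others in the source may bear on it.

Measured so far:
compound 1 `Cc1cc(Cl)ccc1CC(C)C(=O)N1CCN(c2ccc(C(F)(F)F)cc2[C@@H](N)CC(C)C)CC1`: 38 nM
compound 2 `Cc1cc(CC(C)C(=O)N2CCN(c3ccc(C(F)(F)F)cc3[C@@H](N)CC(C)C)CC2)ccc1Cl`: 71 nM

In an assay on HEK293 cells for displacement of a labelled ligand from Melanocortin receptor 4 (Homo sapiens) (on this read-out lower numbers stand for stronger inhibition and higher numbers for weaker inhibition), compound 1 gives 38 nM, the lowest of the two numbers; the step of a 1.9-fold higher number from compound 1 to compound 2 (0.27 log units; within the scatter) lies within the scatter, so no order between compound 1 and compound 2 is claimed. Compound 3 `CC(C)C[C@H](N)c1cc(C(F)(F)F)ccc1N1CCN(C(=O)CC(C)C(=O)c2ccc(Cl)cc2)CC1` is not yet measured in this assay. Against compound 1 the difference is 2-((4-chlorophenyl)carbonyl)propyl in place of 1-(4-chloro-2-methylbenzyl)ethyl on a carbonyl carbon.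

For the measured compounds named here, only one measured step exists, and it concerns a different place: from compound 1 to compound 2 the aryl group changes while the chain is kept, and the number hardly moves. That step says nothing direct about replacing the whole 1-(4-chloro-2-methylbenzyl)ethyl chain with a 2-((4-chlorophenyl)carbonyl)propyl chain, which brings an additional carbonyl and one hydrogen-bond acceptor into the chain. Going by the values given here, no measured pair covers such a change, so the expectation rests on compound 1 alone and carries a wide range.

Compound 3 is expected to give roughly 90 nM in this assay, between 25 nM and 350 nM. This estimate means a step of a 2.4-fold higher number from compound 1 to compound 3 (0.37 log units; beyond the scatter), a mild weakening that is not firmly expected to exceed the scatter.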

Compound 3, inhibition constant: 1100 nM
Compound 3: middle estimate off by 12-fold (1.09 log units), on the low side, and the stated range ends below it.
By their numbers in this assay, from the lowest: compounds 1 and 2 (each within the scatter of the next); then compound 3.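

In this assay, 2-((4-chlorophenyl)carbonyl)propyl on the carbonyl carbon gives a 29-fold higher number from compound 1 to compound 3 (1.46 log units; beyond the scatter) and a 15-fold higher number from compound 2 to compound 3 (1.19 log units; beyond the scatter), so both large steps lead to the same new chain, whichever methyl-bearing chain it replaces. The position, a carbonyl carbon whose other neighbour is an amide-type nitrogen in a ring, is therefore sensitive to the change of chain, which the aryl change alone did not reveal, as a 1.9-fold higher number from compound 1 to compound 2 (0.27 log units; within the scatter) stays within the scatter. The change combines a new chain carbonyl, a rearranged chain and the loss of the ring methyl, and nothing available separates these parts or explains the loss.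

Still open, as far as these compounds go, is how the number responds when a hydroxyl or an ether oxygen stands in place of the chain carbonyl, and whether a methyl on the 4-chlorophenyl ring of the new chain recovers any of the loss. Equally open, from the compounds shown here alone, is whether a shorter chain carrying the same carbonyl, or an amine in its place, behaves like compound 3 or like compound 1.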